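Working notes on the methyl ester series, compounds 1 to 4

The compounds below may be only part of what the source reports. "The series", "measured", "known", "first", "only" and "open" are said of these compounds alone.

Compound 3 `COC(=O)c1ccccc1-c1ccc(CNc2nccc(C)c2NC(=O)CC#N)cc1` gives 11 nM in an assay on isolated protein for binding affinity to B1 bradykinin receptor (Homo sapiens) (on this read-out higher numbers stand for weaker inhibition and lower numbers for stronger inhibition), the lowest of the three numbers. Compound 2 `COC(=O)C1=C(c2ccc(CNc3nccc(C)c3NC(=O)CC#N)cc2)CCC1` gives 126 nM and compound 1 `COC(=O)c1ccccc1C1CCC(CNc2nccc(C)c2NC(=O)CC#N)CC1` gives 385 nM in this assay. Going by the values given here, the one measured step that changes only the group replaced here is an 11-fold lower number from compound 2 to compound 3 (1.06 log units; beyond the scatter); compound 1 differs from compound 3 in more than one place. Compound 4 `COC(=O)c1cccn1-c1ccc(CNc2nccc(C)c2NC(=O)CC#N)cc1` carries 2-(methoxycarbonyl)-1H-pyrrol-1-yl in place of 2-(methoxycarbonyl)phenyl on an aromatic carbon. Among the compounds with values here, no measured step swaps a six-membered aromatic ring of carbon only for a five-membered aromatic ring with one hetero atom, so the step of an 11-fold lower number from compound 2 to compound 3 (1.06 log units; beyond the scatter) bears on it only by showing that this group moves the number strongly. A moderate rise in this assay is expected, a 3.6-fold higher number from compound 3 to compound 4 (0.56 log units; beyond the scatter). Compound 4 is estimated at 40 nM, within 10 nM to 160 nM.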

Compound 4, inhibition constant: 250 nM
Compound 4: middle estimate off by 6.3-fold (0.80 log units), on the low side; measured number outside the range, above it.
By their numbers in this assay, from the lowest: compound 3; then compounds 2, 4 and 1 (each within the scatter of the next, the first and the last beyond it).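

In this assay, 2-(methoxycarbonyl)-1H-pyrrol-1-yl in place of 2-(methoxycarbonyl)phenyl gives a 23-fold higher number from compound 3 to compound 4 (1.36 log units; beyond the scatter) at this place, so the five-membered aromatic ring with one hetero atom does not stand in for the six-membered aromatic ring of carbon only, even with the ester retained. Against 2-(methoxycarbonyl)cyclopent-1-en-1-yl, the same group shows a 2.0-fold higher number from compound 2 to compound 4 (0.30 log units; within the scatter), which sets no order between these two. Nothing on hand accounts for the rise. The compounds shown leave open how a carboxylic acid or a primary amide in place of the methyl ester would read on the phenyl group, and how a pyridine ring carrying the ester would compare.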